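The source may report more compounds than this note shows. Statements on the series, on what has been measured and on what is new or still open speak of the compounds shown alone.

Measured compounds:
compound 1, `O=C(Nc1cccc(C(F)(F)F)c1)N[C@H]1CC[C@H](Oc2ccccc2F)CC1`, 2450 nM
compound 2, `O=C(Nc1ccccc1I)N[C@H]1CC[C@H](Oc2ccc(F)cc2)CC1`, > 20000 nM

Within the data shown here, in a functional assay on CRL2813 cells (Homo sapiens) for cytotoxicity, read by sulforhodamine B assay, with a stated time of 5 days (on this read-out higher numbers stand for weaker inhibition and lower numbers for stronger inhibition), compound 1 gives 2450 nM, the only number reported so far. Compound 2 gives only > 20000 nM, which is a limit of the assay and not a number, one of the two values sitting at the limit of > 20000 nM in this assay, at which 1 of the 2 values shown sits.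

Compound 3, `O=C(Nc1cccc(C(F)(F)F)c1)N[C@H]1CC[C@H](Oc2ccc(C(F)(F)F)cc2)CC1`, differs from compound 1 by 4-(trifluoromethyl)phenyl in place of 2-fluorophenyl on an oxygen on a saturated carbon. Among the measured compounds shown here, no measured pair covers this change, so the step from compound 1 to compound 3 in this assay is expected to be a 1.2-fold lower number from compound 1 to compound 3 (0.09 log units; within the scatter), within the usual scatter. Compound 3 is estimated at 2000 nM, with a range from 500 nM to 8000 nM.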

Compound 3, half-maximal inhibitory concentration: 460 nM
Compound 3: the middle estimate sits 4.3-fold (0.64 log units) above what was measured; measured number below the stated range.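

In this assay, the group on the oxygen on a saturated carbon is not silent: 4-(trifluoromethyl)phenyl in place of 2-fluorophenyl gives a 5.3-fold lower number from compound 1 to compound 3 (0.73 log units; beyond the scatter). Among these compounds, this is the first readable step, and it shows that the number moves with this group while the rest of the core of compound 1 stays fixed. Nothing shown gives a reason for this step.

The two groups differ both in what the ring carries and in its printed ring number, and the compounds shown do not separate these. As far as these compounds go, how a nitrile or an amine on that phenyl would read remains open.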